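A few compounds are considered here, and "the series" means these few. Any claim that something is new, unique, unknown or untested is made for them only; others in the source may bear on it.

Compound 1 `C[C@H](NC(=O)[C@@]1(Cc2ccccc2)CCN1C(=O)OCc1ccccc1)C(=O)NCc1ccccc1` carries a benzyl group on its terminal amide nitrogen. In an ADME assay on HELF cells (Homo sapiens) for cytotoxicity, with a stated time of 3 days (a lower number here means that less compound is tolerated, a higher number that more compound is tolerated), compound 1 gives >= 20000 nM, which is a limit of the assay and not a number. Compound 3 `C[C@H](NC(=O)[C@]1(Cc2ccccc2)CCN1C(=O)OCc1ccccc1)C(=O)NCc1ccccc1`, the same atoms and bonds with one stereocentre drawn the other way, gives 100000 nM in this assay. The step that the limit leaves unreadable from compound 1 to compound 3 cannot be sized due to the limit of >= 20000 nM in this assay, at which 1 of the 3 values shown sits. Compound 2 `C[C@H](NC(=O)[C@]1(Cc2ccccc2)CCN1C(=O)OCc1ccccc1)C(=O)N(C)C` gives > 100000 nM in this assay, again a limit. From the compounds shown here alone, the step of a number no higher from compound 2 to compound 3 (the limit leaves the size open) is likewise open in size. Compound 4 `C[C@H](NC(=O)[C@@]1(Cc2ccccc2)CCN1C(=O)OCc1ccccc1)C(=O)NC(C)(C)C` is compound 1 with tert-butyl in place of benzyl on an amide-type nitrogen. Going by the values given here, no measured step covers this change; every value so far sits at or near the top of the range. For compound 4 the expected step is a step that the limit leaves unreadable from compound 1 to compound 4, nothing beyond the scatter. Compound 4 is therefore expected to give about 100000 nM in this assay, between 30000 nM and 200000 nM, quite possibly reported only as a limit.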

Compound 4, minimum cytotoxic concentration: > 100000 nM
Compound 4: a limit, no number; the forecaster's own chance of this, stated with the estimate: 60%; the middle value sits exactly at the limit.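

Compound 1 and compound 4 are both reported only as limits in this assay, so no step can be read between them. The compounds shown leave open whether tert-butyl in place of benzyl on an amide-type nitrogen changes the minimum cytotoxic concentration at all.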